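This account rests on a few compounds, and the source may have more. Where it says the series, first, only, none or still open, it means among the compounds named here.

Measured so far in an assay on membranes from HEK293 cells for displacement of a labelled ligand from D(4) dopamine receptor (Homo sapiens), read by scintillation counting, with a stated time of 60 min; on this read-out lower numbers stand for stronger inhibition and higher numbers for weaker inhibition:
- compound 2 `OC(Cc1ccccc1)CN1CCC(NCCSC(c2ccc(F)cc2)c2ccc(F)cc2)CC1` gives 2200 nM
- compound 1 `[O-][S+](CCNC1CCN(Cc2ccc(F)cc2)CC1)C(c1ccc(F)cc1)c1ccc(F)cc1` gives 76800 nM

Compound 2 holds the lowest number of the two; compound 1 sits far above it, well beyond the scatter. Within the data shown here, no step between two measured compounds differing in one place is available, so the series gives no direct guide for the next change.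

Compound 3 `O=C(c1ccc(F)cc1)N1CCC(NCCSC(c2ccc(F)cc2)c2ccc(F)cc2)CC1` is not yet measured. It differs from compound 2 by (4-fluorophenyl)carbonyl in place of 2-hydroxy-3-phenylpropyl on an amine nitrogen in a ring. The expectation is a rise in the number beyond the scatter, a step of a 3.6-fold higher number from compound 2 to compound 3 (0.56 log units; beyond the scatter). Compound 3 is thus estimated at 8000 nM, with a range from 2000 nM to 40000 nM.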

Compound 3, inhibition constant: 9020 nM
The estimate for compound 3 lay 1.1-fold (0.05 log units) below the measured number, within the range that was stated.
By their numbers in this assay, from the lowest: compound 2; then compound 3; then compound 1.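

Among these compounds, on the amine nitrogen in a ring, (4-fluorophenyl)carbonyl in place of 2-hydroxy-3-phenylpropyl gives a 4.1-fold higher number from compound 2 to compound 3 (0.61 log units; beyond the scatter) in this assay, the first direct step and a modest one. The change removes the hydrogen-bond donor and adds a fluorine and a double bond outside aromatic rings, while a six-membered aromatic ring remains on both sides. Nothing available explains the step. Which part of the change carries the step stays open. Plain 3-phenylpropyl or unsubstituted benzoyl on this nitrogen would separate these parts.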